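A few compounds are considered here, and "the series" means these few. Any claim that something is new, unique, unknown or untested is made for them only; others in the source may bear on it.

Working notes on the series.

The series shares a sulfonamide-ether-amide core and varies the amine end. Compound 1 `COc1cc(C)c(S(=O)(=O)N(C)CCOCC(=O)N2CCC(N3CCN(C(C)C)CC3)CC2)c(C)c1` in an ADME assay on Caco-2 cells (Homo sapiens) for permeability, tested at 50 uM (on this read-out higher numbers stand for higher permeability and lower numbers for lower permeability), gives 0.9 10^-6 cm/s. Compound 2 `CCN(CC)CCN1CCN(C(=O)COCCN(C)S(=O)(=O)c2c(C)cc(OC)cc2C)CC1` in this assay gives 0.9 10^-6 cm/s. Compound 3 `COc1cc(C)c(S(=O)(=O)N(C)CCOCC(=O)N(C)Cc2ccc(C3=NCCN3)cc2)c(C)c1` in this assay gives 1.3 10^-6 cm/s. Compound 2 is level with compound 1 at the digits shown, the two together being the lowest of the three numbers; its nearest neighbour is compound 1, with no change at the digits shown and within the scatter, and the furthest is compound 3, whose number is higher but still within the scatter. All three numbers therefore sit in one band.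

Compound 4 `CCN1CCC(N2CCN(C(=O)COCCN(C)S(=O)(=O)c3c(C)cc(OC)cc3C)CC2)CC1` has not been measured in this assay. It differs from compound 2 as follows: 1-ethylpiperidin-4-yl in place of 2-(diethylamino)ethyl on an amine nitrogen in a ring. Among the measured compounds shown here, no measured pair isolates this change. Compound 1, which carries a related ring-bearing amine end, gives 0.9 10^-6 cm/s there, and on that basis no step beyond the scatter is expected in either direction for this assay. The step from compound 2 is estimated as no change at the digits printed from compound 2 to compound 4 (within the scatter). Compound 4 is estimated to give 0.9 10^-6 cm/s, expected in the range 0.5 10^-6 cm/s to 1.8 10^-6 cm/s.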

Compound 4, apparent permeability: 1.7 10^-6 cm/s
The estimate for compound 4 lay 1.9-fold (0.28 log units) below the measured number; low and high end bracket the measured number.
By their numbers in this assay, from the lowest: compounds 1, 2, 3 and 4 (each within the scatter of the next).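

Among the compounds shown here, this pair gives the first direct reading at this position: on the amine nitrogen of the piperazine-free description aside, the swap of 2-(diethylamino)ethyl for 1-ethylpiperidin-4-yl gives in this assay a 1.9-fold higher number from compound 2 to compound 4 (0.28 log units; within the scatter).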